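A pyridin-3-yl swap on the amide-type nitrogen

This account rests on a few compounds, and the source may have more. Where it says the series, first, only, none or still open, it means among the compounds named here.

In an in vitro ADME assay on microsomes from liver (Homo sapiens) for pharmacokinetics, read by LC-MS, with a stated time of 10 min, tested at 1 uM (a higher number here means faster removal of the compound, a lower number slower removal), compound 1 `Cc1cc(NC(=O)[C@H]2CN(C)C[C@@H]2c2ccc(/C=C/C(=O)Nc3ccccc3N)cc2)ccc1Cl` gives 15 mL/min/kg and compound 2 `CN1C[C@H](C(=O)Nc2ccc(Cl)cc2F)[C@@H](c2ccc(/C=C/C(=O)Nc3ccccc3N)cc2)C1` gives 11 mL/min/kg so the two stand within the scatter of each other. Compound 3 `CN1C[C@H](C(=O)Nc2cccnc2)[C@@H](c2ccc(/C=C/C(=O)Nc3ccccc3N)cc2)C1` differs from compound 2 through pyridin-3-yl in place of 4-chloro-2-fluorophenyl on an amide-type nitrogen on an amide-type nitrogen. Among the compounds with values here, the one measured step at this place is a 1.4-fold lower number from compound 1 to compound 2 (0.13 log units; within the scatter) and it exchanged one substituted phenyl for another, so it is a weak guide to a ring with a hetero atom. The expected size is therefore a 1.1-fold lower number from compound 2 to compound 3 (0.04 log units; within the scatter) with no step beyond the scatter foreseen. Compound 3 is estimated at 10 mL/min/kg with an expected range from 5 mL/min/kg to 20 mL/min/kg for now.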

Compound 3, clearance: 10 mL/min/kg
Beside the measured number, compound 3's estimate shows no gap at the digits printed, within the range that was stated.
By their numbers in this assay, from the lowest: compounds 3, 2 and 1 (each within the scatter of the next).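

On the amide-type nitrogen, a ring with a hetero atom now stands in place of a substituted phenyl, and this assay gives a 1.1-fold lower number from compound 2 to compound 3 (0.04 log units; within the scatter), while the comparison with the other phenyl gives a 1.5-fold lower number from compound 1 to compound 3 (0.18 log units; within the scatter). This position has so far taken two halogen-bearing phenyl groups and pyridin-3-yl without any step beyond the scatter. No measurement shown here bears on what lies behind these numbers. On these data alone, whether an amine or a carboxylic acid on this ring, or an open alkyl chain in its place, would give a step beyond the scatter stays open.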